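The source may hold more compounds than are shown below. What is called first, only, known or untested is meant among the compounds shown, and "the series" means these compounds.

Compound 1 `CC1=C(c2ccc(O)cc2)C(c2ccc(OC[C@H](C)N3CC[C@@H](C)C3)cc2)Oc2cc(O)ccc21`: 120 ng.h/mL
Compound 2 `CC1=C(c2ccc(S(C)(=O)=O)cc2)C(c2ccc(OC[C@H](C)N3CC[C@@H](C)C3)cc2)Oc2ccc(O)cc21`: "not determined" (no result reported)

In an ADME assay on the whole organism for pharmacokinetics, with Mus musculus as the target, at a dose of 10 mg/kg by the oral route (a lower number here means less compound in the circulation, a higher number more compound in the circulation at the dose given), compound 1 gives 120 ng.h/mL. Compound 2 stands at no single number: its entry reads "not determined" (no result reported). Compound 3 `CC1=C(c2ccc(O)cc2)C(c2ccc(OC[C@H](C)N3CC[C@@H](C)C3)cc2)Oc2ccc(O)cc21` has not yet been measured. The change from compound 2 to compound 3 is hydroxy in place of methylsulfonyl on an aromatic carbon. Among the measured compounds shown here, with no number for compound 2, no step can be placed against it, so the expectation rests on compound 1, whose 120 ng.h/mL is the only number at hand. Compound 3 is expected to give 120 ng.h/mL, within 40 ng.h/mL to 360 ng.h/mL, as an estimate near compound 1 rather than a step in either direction.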

Compound 3, area under the concentration-time curve: 460 ng.h/mL
The estimate for compound 3 lay 3.8-fold (0.58 log units) below the measured number; measured number outside the range, above it.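

Among the compounds shown here, compound 2 has no single number in this assay and so no step to compound 3 can be read. The compounds shown leave open what swapping methylsulfonyl for hydroxy does on its own, and no evidence here bears on this result.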